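Replacing a Branched Acrylamide Terminus by a Linear Butenyl Chain

The source may report more compounds than this note shows. Statements on the series, on what has been measured and on what is new or still open speak of the compounds shown alone.

Measured compounds: compound 1 `C=C(Cl)C(=O)Nc1cc(Nc2nccc(-c3cn(C)c4ccccc34)n2)c(OC)cc1N(C)CCN(C)C` gives 1290 nM in a functional assay on NCI-H1975 cells (Homo sapiens) for antiproliferative activity, read by MTT assay, with a stated time of 72 h; a higher number here means a weaker inhibitor, a lower number a stronger inhibitor; compound 2 `COc1cc(N(C)CCN(C)C)c(NC(=O)C=C(C)C)cc1Nc1nccc(-c2cn(C)c3ccccc23)n1` gives 5610 nM in this assay.

Compound 2 carries the highest number of the two compounds measured in this assay; its nearest neighbour, compound 1, is separated from it by a 4.3-fold higher number from compound 1 to compound 2 (0.64 log units; beyond the scatter), a modest step beyond the scatter. Compound 3 `CC/C=C\C(=O)Nc1cc(Nc2nccc(-c3cn(C)c4ccccc34)n2)c(OC)cc1N(C)CCN(C)C` is the next compound to be considered. It differs from compound 2 in one place: but-1-en-1-yl in place of 2-methylprop-1-en-1-yl on a carbonyl carbon. For the measured compounds named here, the only measured step that touches this carbonyl carbon is the one from compound 1 to compound 2, which exchanged the 1-chloroethenyl group for the 2-methylprop-1-en-1-yl group and raised the number. Going by the values given here, compound 3 moves to a but-1-en-1-yl group, a change of branching at the same position rather than a return to the chlorinated group, so no directly matching step exists. A step of modest size toward a lower number is therefore expected for compound 3, a 2.2-fold lower number from compound 2 to compound 3 (0.35 log units; beyond the scatter), while a result within the scatter of compound 2 cannot be excluded. Compound 3 is estimated at 2500 nM, with a range from 900 nM to 7000 nM.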

Compound 3, half-maximal inhibitory concentration: 3860 nM
Estimate against measurement, compound 3: 1.5-fold (0.19 log units) below; low and high end bracket the measured number.
By their numbers in this assay, from the lowest: compound 1; then compounds 3 and 2 (each within the scatter of the next).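

In this assay, exchanging the 2-methylprop-1-en-1-yl group on the carbonyl carbon for the but-1-en-1-yl group, which has the same atoms joined differently, gives a 1.5-fold lower number from compound 2 to compound 3 (0.16 log units; within the scatter), so branching within this four-carbon group does not separate the two compounds here. The comparison with the chlorinated group gives a 3.0-fold higher number from compound 1 to compound 3 (0.48 log units; beyond the scatter), so compound 1 now stands apart from two different four-carbon groups, each with a step beyond the scatter, and not from a single one as before. Nothing shown here accounts for either step, and no supporting measurement bears on this result.

The compounds shown leave open how an unsubstituted ethenyl group or a 1-fluoroethenyl group on the same carbonyl carbon would compare with the 1-chloroethenyl group of compound 1. They also leave open whether a longer chain, or a butenyl chain carrying a dimethylamino group, would give a number beyond the scatter of compound 3.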